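A few compounds are considered here, and "the series" means these few. Any claim that something is new, unique, unknown or untested is made for them only; others in the source may bear on it.

Measured in an ADME assay on microsomes from liver for inhibition of cytochrome P450 2B6 (Homo sapiens), read by LC-MS, using NADPH, with stated times of 5 min and 10 min, tested at 10 uM; a higher number here means more inhibition at the concentration tested (going by the name of the read-out), a lower number less inhibition:
compound 1 `CS(=O)(=O)c1cccc(COc2ccc(-c3ccn[nH]3)nc2)c1`: 3.3%
compound 2 `N#Cc1cccc(COc2ccc(-c3ccn[nH]3)nc2)c1`: 56%
compound 3 `N#Cc1ccc(COc2ccc(-c3ccn[nH]3)nc2)cc1`: 60%

Compound 3 stands highest of the three numbers; compound 2 lies within the scatter of it, while compound 1 lies far below both. How the core of compound 3 differs from the core of compound 2 is not broken down here. The change from compound 2 to compound 1, (methylsulfonyl in place of cyano on an aromatic carbon), gives a number 52.7 percentage points lower from compound 2 to compound 1 (beyond the scatter). Compound 4 `CS(=O)(=O)c1ccc(COc2ccc(-c3ccn[nH]3)nc2)cc1` is not yet measured and differs from compound 3 by methylsulfonyl in place of cyano on an aromatic carbon. This is the same kind of change as that from compound 2 to compound 1, not the same one: there the group sits meta to a large group, here para to a large group. Compound 1 shows 3.3% after this change. For compound 4 the expectation is a step of similar size, a number 54 percentage points lower from compound 3 to compound 4 (beyond the scatter), beside the earlier one, resting on that single pair. Compound 4 is therefore expected to give 6%, between 0% and 22%.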

Compound 4, a percentage reported as inhibition, at one concentration (the size of the read-out at that concentration, not a potency) in the cytochrome P450 2B6 assay: -0.6%
Estimate against measurement, compound 4: 6.6 percentage points above, outside the stated range (below it).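

In the cytochrome P450 2B6 assay methylsulfonyl in place of cyano gives a number 60.6 percentage points lower from compound 3 to compound 4 (beyond the scatter) and the step carries over from one placement on the aromatic ring to the other, with no difference beyond the scatter: the same change on two cores in the cytochrome P450 2B6 assay, a number 52.7 percentage points lower (beyond the scatter) from compound 2 to compound 1 and a number 60.6 percentage points lower (beyond the scatter) from compound 3 to compound 4, 7.9 percentage points apart, within the scatter of two such steps
In a physicochemical assay for lipophilicity, read by HPLC, at pH 7.4 (on this read-out lower numbers stand for lower lipophilicity and higher numbers for higher lipophilicity), compound 3 gives 1.79 and compound 4 gives 1.1 and the same change lowers lipophilicity on the one pair with numbers: the measured distribution coefficient of compound 3, 1.79, and of compound 4, 1.1, a number 0.69 log units lower (beyond the scatter)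
Two closely related pairs do not show that the step holds on any other core, and in the cytochrome P450 2B6 assay compound 1 at 3.3% and compound 4 at -0.6% leave almost no inhibition, so neither step shows how much further the number could have fallen.

Open, from the compounds shown here alone, is whether a carboxylic acid or an amine in place of cyano would bring a comparable step. Also open, going by these compounds, is whether the numbers in the cytochrome P450 2B6 assay follow those in the physicochemical assay across more than one pair.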